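Compound 4: One Group Changes, Clearance Still Unknown

The compounds below may be only part of what the source reports. "The series", "measured", "known", "first", "only" and "open" are said of these compounds alone.

Three related compounds have been tested in an ADME assay on microsomes from liver (Mus musculus) for metabolic stability, read by LC-MS, using NADPH, with stated times of 10 min and 30 min, tested at 1 uM; on this read-out higher numbers stand for fast clearance and lower numbers for slow clearance. Compound 1 `COC(=O)C1=C(C)NC(c2nccs2)=NC1(C)c1ccc(Cl)cc1` gives 85 mL/min/kg, compound 2 `COC(=O)C1=C(C)NC(c2nccs2)=NC1(C)c1ccc(F)c(F)c1` gives 83 mL/min/kg, and compound 3 `COC(=O)C1=C(CN2CC3CC2CO3)NC(c2nccs2)=NC1(C)c1ccc(F)cc1` gives 84 mL/min/kg. Compound 3 therefore has no distinct place among them: its number lies within the usual scatter of both others, so the three cannot be ranked.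

Compound 4 `COC(=O)C1=C(CN2CCC(C(F)(F)F)C2)NC(c2nccs2)=NC1(C)c1ccc(F)cc1` has not yet been measured. It differs from compound 3 in one place: a group of 9 heavy atoms (5 carbon, 1 nitrogen, 3 fluorine; one five-membered non-aromatic ring with 1 hetero atom) in place of a group of 7 heavy atoms (5 carbon, 1 nitrogen, 1 oxygen; 2 five-membered non-aromatic rings with 1 hetero atom each), on a saturated chain carbon bound to a double-bonded ring carbon. The incoming group is 3-(trifluoromethyl)pyrrolidin-1-yl.

Among the compounds with values here, only one measured step links two compounds that differ in a single place: a 1.0-fold lower number from compound 1 to compound 2 (0.01 log units; within the scatter). Within the data shown here, that step lies within the scatter, but it concerns a different part of the molecule, so no measurement yet tests a change at the place where compound 4 differs. This makes any forecast a weak one. Among the measured compounds shown here, with compound 3 at 84 mL/min/kg as the starting point, and that single step as the only guide, no shift beyond the scatter is expected. The estimated step is a 1.1-fold lower number from compound 3 to compound 4 (0.02 log units; within the scatter). For compound 4, the expected clearance is 80 mL/min/kg, with an estimated range from 50 mL/min/kg to 110 mL/min/kg.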

Compound 4, clearance: 88 mL/min/kg
Estimate against measurement, compound 4: 1.1-fold (0.04 log units) below; the range from low to high includes it.
By their numbers in this assay, from the lowest: compounds 2, 3, 1 and 4 (each within the scatter of the next).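

In this assay, replacing the group with two five-membered non-aromatic rings by 3-(trifluoromethyl)pyrrolidin-1-yl, on a saturated chain carbon bound to a double-bonded ring carbon, gives a 1.0-fold higher number from compound 3 to compound 4 (0.02 log units; within the scatter). Within the data shown here, this is the first measured step at this place, and it shows that this exchange, which takes out an oxygen and brings in three fluorines, leaves compound 4 indistinguishable from compound 3 on this read-out. Nothing at hand explains the result, so the absence of a shift has no known cause.

A single step cannot show whether clearance is insensitive to every change at this place: an open-chain amine such as diethylamino, or a group carrying a carboxylic acid, on the same carbon might or might not produce a step beyond the scatter. From the compounds shown here alone, it also remains open whether a change elsewhere on the molecule, such as a carboxylic acid in place of the methyl ester, would move the number in a way that this exchange does not.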